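The source may hold more compounds than are shown below. What is called first, only, known or untested is meant among the compounds shown, and "the series" means these compounds.

Measured in an ADME assay on HEK-293T cells (Homo sapiens) for cytotoxicity, read by resazurin assay, with a stated time of 16 h; a higher number here means a weaker inhibitor, a lower number a stronger inhibitor:
Compound 1 `OC[C@H]1O[C@@H](n2cnc3c(NC4CCCC4)nc(NC4CCCC4)nc32)[C@H](O)[C@@H]1O`: > 500000 nM
Compound 2 `OC[C@H]1O[C@@H](n2cnc3c(NCCC(c4ccccc4)c4ccccc4)nc(NCc4cccc5ccccc45)nc32)[C@H](O)[C@@H]1O`: "not determined" (no result reported)

The entry for compound 1 is a limit of the assay and not a number. Compound 2 has no usable result, and its entry reads "not determined" (no result reported). Going by the values given here, no pair of measured compounds therefore shows how a structural change acts in this assay.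

Compound 3 `OC[C@H]1O[C@@H](n2cnc3c(NC4CCCC4)nc(NC4CC4)nc32)[C@H](O)[C@@H]1O` has yet to be measured. It differs from compound 1 in one place, with cyclopropyl in place of cyclopentyl on a nitrogen on an aromatic ring. The change from cyclopentylamino to cyclopropylamino is expected to give no step beyond the scatter, in either direction. This expectation rests on compound 1 alone, with the limit of > 500000 nM in this assay, at which 1 of the 2 values shown sits. The estimated step runs a number no higher from compound 1 to compound 3 (the limit leaves the size open). For compound 3 the expected value is 500000 nM, with an estimated range of 200000 nM to 800000 nM.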

Compound 3, half-maximal inhibitory concentration: > 500000 nM
Compound 3: no number, only a limit; the forecaster's own chance of this, stated with the estimate: 75%; the middle value lies on the limit itself.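

Compound 1 and compound 3 both stand at a limit of the assay and not at a number, so no step between them can be read: the limit of > 500000 nM in this assay, at which 2 of the 3 values shown sit.

The compounds shown leave open whether any structural change would give a measurable value.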